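A few compounds are considered here, and "the series" means these few. Any claim that something is new, unique, unknown or untested is made for them only; others in the source may bear on it.

Of the compounds shown here, two have been measured in an ADME assay on HT-29 cells (Homo sapiens) for cytotoxicity, read by MTT assay, with a stated time of 72 h; on this read-out lower numbers stand for stronger inhibition and higher numbers for weaker inhibition. Compound 1 `COc1ccc(C2=C(c3cc(OC)c(OC)c(OC)c3)C(=O)C(OC(C)=O)C2)cc1F` gives < 1 ug/mL, which is a limit of the assay and not a number. Compound 2 `COc1ccc(C2=C(c3cc(OC)c(OC)c(OC)c3)C(=O)C(O)C2)cc1Cl` gives < 1 ug/mL, which is also a limit and not a number. The standing of compound 2 is therefore known only as the limit of < 1 ug/mL in this assay, at which 2 of the 2 values shown sit. Compound 3 `COc1ccc(C2=C(c3cc(OC)c(OC)c(OC)c3)C(=O)C(O)C2)cc1F` departs from compound 2 in one place: fluoro in place of chloro on an aromatic carbon. This is fluoro in place of chloro on an aromatic carbon, so that 3-chloro-4-methoxyphenyl becomes 3-fluoro-4-methoxyphenyl. Among the compounds with values here, no measured pair shows this exchange, and the limits give no exact starting number. No change beyond the usual scatter is expected, in either direction. The expected move is a step that the limit leaves unreadable from compound 2 to compound 3. For compound 3 the estimated value in this assay is 0.4 ug/mL, with an expected range from 0.08 ug/mL to 1.5 ug/mL.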

Compound 3, half-maximal inhibitory concentration: < 1 ug/mL
Compound 3: no number, only a limit; the forecaster's own chance of this, stated with the estimate: 65%; the middle value is on the limit's open side.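

Compound 3 also returns only a limit, so no step from compound 2 to compound 3 or from compound 1 to compound 3 can be read: the limit of < 1 ug/mL in this assay, at which 3 of the 3 values shown sit.

The compounds shown leave open whether fluoro in place of chloro, or hydrogen in place of acetyl on the oxygen, changes the read-out in this assay at all.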